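A few compounds are considered here, and "the series" means these few. Any claim that something is new, unique, unknown or untested is made for them only; others in the source may bear on it.

Two nucleoside analogues sharing the same sugar part have been tested in a functional assay on CCRF-CEM cells (Homo sapiens) for antiproliferative activity, read by cell counting, with a stated time of 72 h; a lower number here means a stronger inhibitor, a higher number a weaker inhibitor. Compound 1, `C#C[C@@]1(O)[C@@H](CO)O[C@@H](n2cnc3c(-c4ccc(Cl)cc4)ncnc32)[C@@H]1O`, carries a purine-type base bearing a chlorophenyl group; in this assay compound 1 gives 124000 nM. Compound 2, `C#C[C@@]1(O)[C@@H](CO)O[C@@H](n2cc(F)c3c(N)ncnc32)[C@@H]1O`, instead carries an amino-substituted base with a fluoro group on its five-membered ring; in this assay compound 2 gives 160 nM. Of these two numbers, compound 2 has the lower one, and its distance from compound 1 is far beyond the usual scatter, so compound 2 is clearly the stronger inhibitor of the pair.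

Compound 3, `C#C[C@@]1(O)[C@@H](CO)O[C@@H](n2cc(Cl)c3c(N)ncnc32)[C@@H]1O`, is the untested next step. It differs from compound 2 only by chloro in place of fluoro on an aromatic carbon. Among the measured compounds shown here, no measured pair in this set shows what swapping one halogen for another does here, so the expectation rests on compound 2 alone. Because compound 2 already gives 160 nM, the change from fluoro to chloro is expected to move the number only a little, if at all, probably slightly downward but within the scatter. For compound 3 the estimated step of a 1.5-fold lower number from compound 2 to compound 3 (0.16 log units; within the scatter) leads to an expected value of 110 nM, with a likely range from 35 nM to 400 nM.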

Compound 3, half-maximal inhibitory concentration: 12 nM
For compound 3 the middle estimate is 9.2-fold (0.96 log units) above the measured one; measured number below the stated range.
By their numbers in this assay, from the lowest: compound 3; then compound 2; then compound 1.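

Among the compounds shown here, this is the first pair in the set that differs in one place only, and it shows that the choice of halogen on this aromatic carbon of the five-membered ring matters a great deal in this assay: chloro in place of fluoro gives a 13-fold lower number from compound 2 to compound 3 (1.12 log units; beyond the scatter), a large step. The swap trades one heavy atom for one heavy atom, with no ring, no hydrogen-bond donor or acceptor and no net charge entering or leaving, yet the number still moves well beyond the scatter, so this position responds strongly even to a very small change. Nothing available here accounts for why chloro gives the lower number at this position.

The compounds shown leave open how far this trend runs, since a bromo or iodo group, or a methyl or nitrile group, on the same carbon would show whether the number keeps falling or turns back up. This single pair also cannot tell whether the same swap would have a similar effect with a different sugar part or with other groups elsewhere on the base.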